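The source may hold more compounds than are shown below. What is called first, only, known or untested is meant among the compounds shown, and "the series" means these compounds.

Compound 1 `CCC(CC)(c1ccc(OCC(=O)C(C)(C)CCc2ccccc2)c(C)c1)c1ccc(OC[C@@H](O)CO)c(C)c1` gives 23000 nM in an assay on HL-60 cells for activation of vitamin D3 receptor (Homo sapiens); on this read-out higher numbers stand for an effect only at larger amounts of compound and lower numbers for an effect already at smaller amounts.
Compound 2 `CCC(CC)(c1ccc(OCC(O)C(C)(C)CCc2ccccc2)c(C)c1)c1ccc(OC[C@@H](O)CO)c(C)c1` gives 7100 nM in this assay.
Compound 3 `CCC(CC)(c1ccc(OCC(O)C(C)(C)CCCc2ccccc2)c(C)c1)c1ccc(OC[C@@H](O)CO)c(C)c1` gives 3600 nM in this assay.

Compound 3 holds the lowest of the three numbers in this assay, though compound 2 sits nearest and the difference between them lies within the scatter, while compound 1 stands furthest away, beyond it. Compound 4 `CCC(CC)(c1ccc(OCC(O)C(C)(C)Cc2ccc3ccccc3c2)c(C)c1)c1ccc(OC[C@@H](O)CO)c(C)c1` departs from compound 3 by naphthalen-2-yl in place of phenethyl on a saturated chain carbon, three bonds along the chain from an oxygen on a saturated carbon; read one bond further out, the change is 3-phenylpropyl to (naphthalen-2-yl)methyl.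

Among the measured compounds shown here, only one measured step touches this region of the molecule: a 2.0-fold lower number from compound 2 to compound 3 (0.29 log units; within the scatter), a lengthening of the chain between the saturated carbon and the aromatic ring. For the measured compounds named here, the new change shortens that chain again and brings in a second fused ring, a kind of change for which no measured pair exists here. The modest size of the step from compound 2 to compound 3 argues for little movement, and the lack of any precedent for the fused ring widens the uncertainty. Compound 4 is therefore expected to show a step of a 1.0-fold lower number from compound 3 to compound 4 (0.01 log units; within the scatter) in this assay, that is none beyond the scatter. Compound 4 is estimated at 3500 nM, with a range from 1000 nM to 12000 nM.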

Compound 4, half-maximal effective concentration: > 30000 nM
Compound 4: a limit, no number; the forecaster's own chance of this, stated with the estimate: 5%; at least 8.5-fold (0.93 log units) between middle value and limit.
By their numbers in this assay, from the lowest: compounds 3 and 2 (each within the scatter of the next); then compound 1. At a limit, above all of these: compound 4.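

Compound 4 gives no number, only a limit: the limit of > 30000 nM in this assay, at which 1 of the 4 values shown sits. Even so, the steps can be read as lower bounds, an at least 8.3-fold higher number from compound 3 to compound 4 (0.92 log units; beyond the scatter) and an at least 4.2-fold higher number from compound 2 to compound 4 (0.62 log units; beyond the scatter), and both lie beyond the scatter, whereas the only earlier change at this position, a 2.0-fold lower number from compound 2 to compound 3 (0.29 log units; within the scatter), stayed within it. On a saturated chain carbon, three bonds along the chain from an oxygen on a saturated carbon, benzyl and phenethyl give values within the scatter of each other, while naphthalen-2-yl in place of either pushes the read-out clearly upward, so this position does not treat all aromatic groups alike.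

The change to (naphthalen-2-yl)methyl alters the aromatic group and the length of the chain in a single step, so the compounds shown cannot separate the two effects, and how far the true value of compound 4 lies past the limit remains unknown. As far as these compounds go, it also stays open whether a 3-(naphthalen-2-yl)propyl group would keep the values of compound 2 and compound 3, and how an amine or a carboxylic acid at the end of the 3-phenylpropyl chain would read.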